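Replacing the isoxazolyl amide of compound 1 with a pyrrolidine amide

The compounds below may be only part of what the source reports. "The series", "measured", "known", "first", "only" and "open" are said of these compounds alone.

Compound 1 `CCn1c(/C=C2\SC(=O)N(CC(=O)Nc3cc(C(C)(C)C)on3)C2=O)nc2ccccc21` is tested in a functional assay on MDA-MB-231 cells (Homo sapiens) for inhibition, read by MTT assay, with a stated time of 48 h (on this read-out lower numbers stand for stronger inhibition and higher numbers for weaker inhibition), and gives only a limit: in this assay compound 1 gives > 50000 nM. Compound 2 `CC(C)n1c(/C=C2\SC(=O)N(CC(=O)Nc3cc(C(C)(C)C)on3)C2=O)nc2ccccc21` likewise reaches only a limit, giving > 50000 nM in this assay. Compound 3 `CCn1c(/C=C2\SC(=O)N(CC(=O)Nc3nc(-c4ccccc4)cs3)C2=O)nc2ccccc21` is also reported as a limit, giving > 50000 nM in this assay. Accordingly the step that the two limits leave unreadable from compound 1 to compound 2 and the step that the two limits leave unreadable from compound 1 to compound 3 cannot be sized, since every value sits at the limit of > 50000 nM in this assay, at which 3 of the 3 values shown sit.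

Compound 4 `CCn1c(/C=C2\SC(=O)N(CC(=O)N3CCCC3)C2=O)nc2ccccc21` has not yet been measured. It differs from compound 1 by pyrrolidin-1-yl in place of (5-(tert-butyl)-1,2-oxazol-3-yl)amino on a carbonyl carbon. Among the compounds with values here, neither measured step bears on this exchange: the amide-side changes from compound 1 to compound 2 and from compound 1 to compound 3 were both unreadable, and no compound with a number rather than a limit is known. The expectation for compound 4 therefore rests on the limit alone, and a step of a number no higher from compound 1 to compound 4 (the limit leaves the size open) is estimated, with the assay most likely reporting a limit once more. Compound 4 is expected to give about 50000 nM, within 15000 nM to 150000 nM.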

Compound 4, half-maximal inhibitory concentration: > 50000 nM
Compound 4 gave a limit, no number (the forecaster's own chance of this, stated with the estimate: 75%); the middle value sits exactly at the limit.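

Compound 4, like compound 1, gives only a limit in this assay, so the step between these two compounds cannot be read: the limit of > 50000 nM in this assay, at which 4 of the 4 values shown sit.

The compounds shown leave open what change to the shared core or its amide side would give a measurable number in this assay.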